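Adding a Second Chloro Group to a Purine-Type Cytotoxic Agent

The compounds below may be only part of what the source reports. "The series", "measured", "known", "first", "only" and "open" are said of these compounds alone.

Measured compounds:
- Compound 1 `ClCc1cccc(Cn2cnc3ncnc(Cl)c32)c1`: in a functional assay on SF-539 cells (Homo sapiens) for cytotoxicity, read by sulforhodamine B assay, with a stated time of 48 h (a lower number here means that less compound is tolerated, a higher number that more compound is tolerated), compound 1 gives "not determined" (no result reported)
- Compound 2 `ClCc1cccc(Cn2cnc3c(Cl)ncnc32)c1`: in this assay compound 2 gives 61700 nM

Compound 1 carries a single chloro group on its fused core and a chloromethyl-substituted benzyl arm. In this assay compound 1 has no single number: the measurement was not carried out, so nothing is known about how much of it the cells tolerate. Among the measured compounds shown here, the only measured value in this set belongs to compound 2, a positional isomer whose benzyl arm sits on the other ring nitrogen of the core, and that value shows only weak cytotoxicity. For the measured compounds named here, no step connecting compound 1 and compound 2 is available, so their values cannot be compared as a change.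

Compound 3 `ClCc1cccc(Cn2cnc3nc(Cl)nc(Cl)c32)c1` differs from compound 1 by one small change: chloro in place of hydrogen on an aromatic carbon. With no measured starting point for compound 1, the size and direction of the step in this assay cannot be derived from data; the step is expected to be small, either within the scatter or modestly toward more tolerated.

Compound 3 is therefore expected to give about 45000 nM in this assay, most likely within 12000 nM to 170000 nM.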

Compound 3, concentration lethal to 50% of the cells: 1620 nM
For compound 3 the middle estimate is 28-fold (1.44 log units) above the measured one, and the stated range ends above it.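

In this assay, among the compounds shown here, compound 1 has no single number, while compound 3 gives 1620 nM on its own, so no step from compound 1 to compound 3 can be read. Going by these compounds, what the added chloro group does to how much compound the cells tolerate stays open. Nothing shown here offers an explanation for the value of compound 3.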